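The source may report more compounds than this note shows. Statements on the series, on what has been measured and on what is new or still open speak of the compounds shown alone.

Measured so far:
- compound 1 `O=C(CSc1nnnn1-c1cccc2ccccc12)N/N=C/c1ccc(Cl)cc1`: > 295000 nM
- compound 2 `COc1ccc(/C=N/NC(=O)CSc2nnnn2-c2cccc3ccccc23)cc1`: > 298000 nM
- compound 3 `COc1ccc(/C=N/NC(=O)CSc2nnnn2-c2cccc3ccccc23)c(OC)c1`: 28300 nM

In an ADME assay on MT4 cells (Homo sapiens) for cytotoxicity, read by MTT assay (a lower number here means that less compound is tolerated, a higher number that more compound is tolerated), compound 1 gives > 295000 nM, which is a limit of the assay. Compound 2 likewise gives > 298000 nM, also a limit. Within the data shown here, compound 3 is the only compound of the three with a measured number, 28300 nM. Between compound 1 and compound 2 the step is a step that the two limits leave unreadable from compound 1 to compound 2. From compound 2 to compound 3 the step is an at least 10-fold lower number from compound 2 to compound 3 (1.02 log units; beyond the scatter), and from compound 1 to compound 3 it is an at least 10-fold lower number from compound 1 to compound 3 (1.01 log units; beyond the scatter).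

Compound 4 `O=C(CSc1nnnn1-c1cccc2ccccc12)N/N=C/c1ccccc1` is not yet measured. It differs from compound 3 by phenyl in place of 2,4-dimethoxyphenyl on a carbon with a double bond to nitrogen. This removes both methoxy groups whose addition made the step of an at least 10-fold lower number from compound 2 to compound 3 (1.02 log units; beyond the scatter), so the reverse is expected: a large step upward, an 8.8-fold higher number from compound 3 to compound 4 (0.95 log units; beyond the scatter), with a fair chance that this assay again reports only a limit. Compound 4 is therefore expected to give 250000 nM, in the range 60000 nM to 300000 nM.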

Compound 4, half-maximal cytotoxic concentration: 216000 nM
Beside the measured number, compound 4's estimate is 1.2-fold (0.06 log units) above it; low and high end bracket the measured number.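

Phenyl in place of 2,4-dimethoxyphenyl gives a 7.6-fold higher number from compound 3 to compound 4 (0.88 log units; beyond the scatter) in this assay and is the only step at this position with a number at both ends. Hydrogen in place of methoxy gives an at least 1.3-fold lower number from compound 2 to compound 4 (0.13 log units; that floor lies within the scatter) and hydrogen in place of chloro gives an at least 1.3-fold lower number from compound 1 to compound 4 (0.13 log units; that floor lies within the scatter) but both rest on limits of the assay, so compound 4 cannot be ranked against compound 1 or compound 2. Among these compounds, the low number stays with the 2,4-dimethoxyphenyl group of compound 3.

Still open, as far as these compounds go, is whether an amine or a carboxylic acid in place of the methoxy groups would also lower the number. Nothing measured here gives a cause for the step.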